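A Side-Group Swap After a Steep Fall in Growth Inhibition

This account rests on a few compounds, and the source may have more. Where it says the series, first, only, none or still open, it means among the compounds named here.

Measured so far in a functional assay on MV4-11 cells (Homo sapiens) for inhibition, read by luminescence, with a stated time of 72 h, tested at 5 uM; a higher number here means more inhibition of growth at the concentration tested, a lower number less inhibition of growth
- compound 1 (`C=CS(=O)(=O)NC/C=C/c1cc(OC)cc(O)c1C(=O)OC(C)C`) gives 72.3%
- compound 2 (`C=CS(=O)(=O)NC/C=C/c1cc(OC)cc(O)c1C(=O)OCC(C)c1ccccc1`) gives 9.6%

Compound 2 holds the lower of the two numbers. Going by the values given here, the only measured step, a number 62.7 percentage points lower from compound 1 to compound 2 (beyond the scatter), put 2-phenylpropyl in place of isopropyl on an oxygen next to a carbonyl group. Compound 3 (`C=CS(=O)(=O)NC/C=C/c1cc(OC)cc(O)c1C(=O)OCc1ccc(F)cc1`) alters that same group: 4-fluorophenyl in place of 1-phenylethyl on a saturated chain carbon bound to an oxygen next to a carbonyl group. Among the compounds with values here, that single step is the only guide, and it shows that this group can matter greatly. A partial recovery is expected, smaller than that fall, with an estimated a number 22.4 percentage points higher from compound 2 to compound 3 (beyond the scatter). Compound 3 is estimated at 32%, with an expected range of 8% to 70%.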

Compound 3, percent growth inhibition at one concentration: 70.5%
Compound 3: the middle estimate sits 38.5 percentage points below what was measured, and the stated range ends below it.
By their numbers in this assay, from the lowest: compound 2; then compounds 3 and 1 (each within the scatter of the next).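

In this assay, the group on the oxygen next to a carbonyl group can carry an aromatic ring and still give strong growth inhibition: 4-fluorobenzyl in place of 2-phenylpropyl gives a number 60.9 percentage points higher from compound 2 to compound 3 (beyond the scatter), while 4-fluorobenzyl in place of isopropyl gives a number 1.8 percentage points lower from compound 1 to compound 3 (within the scatter). Compound 2 and compound 3 both carry an aromatic ring at this place. Only compound 2 has the low number.

Plain benzyl, without the fluorine, would show whether the fluorine or the shape of the chain carries the step. Nothing available explains why these two groups differ so sharply.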